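A few compounds are considered here, and "the series" means these few. Any claim that something is new, unique, unknown or untested is made for them only; others in the source may bear on it.

Of the compounds shown here, three sharing one core have been measured in a functional assay on MDA-MB-468 cells (Homo sapiens) for inhibition, read by sulforhodamine B assay, with a stated time of 48 h, tested at 10 uM; a higher number here means more inhibition at the concentration tested (going by the name of the read-out), a lower number less inhibition. Compound 1 `COc1ccc(-c2cn3ccnc3c(-c3ccc4ncn(C5CCCCC5)c4c3)n2)cc1` gives 97.4%. Compound 2 `c1ccc2c(-c3cn4ccnc4c(-c4ccc5ncn(C6CCCCC6)c5c4)n3)cccc2c1` gives 10.4%, and compound 3 `Clc1ccc(-c2cn3ccnc3c(-c3ccc4ncn(C5CCCCC5)c4c3)n2)cc1` gives 10.6%. Compound 3 therefore stands second highest of the three numbers: its nearest neighbour is compound 2, separated by a gap within the scatter, and its furthest is compound 1, which lies far above it. Among the measured steps, a number 86.8 percentage points lower from compound 1 to compound 3 (beyond the scatter) and a number 87 percentage points lower from compound 1 to compound 2 (beyond the scatter) are both large falls, whereas a number 0.2 percentage points higher from compound 2 to compound 3 (within the scatter) stays within the scatter.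

Compound 4 `Fc1ccccc1-c1cn2ccnc2c(-c2ccc3ncn(C4CCCCC4)c3c2)n1` has not yet been measured in this assay. It differs from compound 3 in a single place: 2-fluorophenyl in place of 4-chlorophenyl on an aromatic carbon. Two measured steps alter the same aryl group. Both bear on this change: the step from compound 1 to compound 3 was large, and the step from compound 2 to compound 3 was flat. Only compound 1, which carries the methoxy group, reaches a high number, while compound 2 and compound 3 sit low together. For the measured compounds named here, no measured step shows what a fluorine placed as in 2-fluorophenyl does, so the expected step is a number 7.4 percentage points higher from compound 3 to compound 4 (within the scatter), no change beyond the scatter. For compound 4 the estimate in this assay is 18%, within a range from 3% to 55%.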

Compound 4, a percentage reported as inhibition, at one concentration (the size of the read-out at that concentration, not a potency): 27.6%
Compound 4: middle estimate off by 9.6 percentage points, on the low side; the measured number falls inside the stated range.
By their numbers in this assay, from the lowest: compounds 2 and 3 (each within the scatter of the next); then compound 4; then compound 1.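

In this assay the aryl position on the shared core turns out not to be limited to two levels: the change to 2-fluorophenyl gives a number 17 percentage points higher from compound 3 to compound 4 (beyond the scatter) and also a number 17.2 percentage points higher from compound 2 to compound 4 (beyond the scatter) as a second reading of the same gain. The low level shared by compound 2 and compound 3 therefore does not hold for every group other than 4-methoxyphenyl, although the gain is small beside a number 69.8 percentage points lower from compound 1 to compound 4 (beyond the scatter) and compound 4 stays much closer to those two than to compound 1. No measured evidence is available to explain any of these differences.

From the compounds shown here alone, what remains open is whether the gain with compound 4 follows from the halogen or from its place on the phenyl ring, since 2-fluorophenyl and 4-chlorophenyl differ in both, and 4-fluorophenyl or 2-chlorophenyl would separate the two. Going by these compounds, it is also open whether the high number of compound 1 is tied to the methoxy group itself or to its place on the ring, a question that 2-methoxyphenyl, 4-ethoxyphenyl or 4-aminophenyl would address.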